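From pyrazolyl to isobutyl on the amide nitrogen

The source may report more compounds than this note shows. Statements on the series, on what has been measured and on what is new or still open speak of the compounds shown alone.

In an assay on HEK293 cells for agonist activity at transient receptor potential cation channel subfamily M member 8 (Homo sapiens), read by fluorescence and calcium flux, with a stated time of 15 min (on this read-out lower numbers stand for an effect already at smaller amounts and higher numbers for an effect only at larger amounts of compound), compound 3 `Cc1ccc(OCC(=O)N(Cc2cccs2)c2c[nH]nc2C)cc1` gives 0.4 nM, the lowest of the three numbers recorded. Compound 1 `CCN(Cc1ccc(C)s1)C(=O)COc1ccc(C)cc1` gives 178 nM, and compound 2 `CCN(Cc1cccn1C)C(=O)COc1ccc(C)cc1` gives 21300 nM. Compound 4 `Cc1ccc(OCC(=O)N(Cc2cccs2)CC(C)C)cc1` is the next candidate; its change from compound 3 is isobutyl in place of 3-methyl-1H-pyrazol-4-yl on an amide-type nitrogen. Among the compounds with values here, the only single-point step measured, a 120-fold higher number from compound 1 to compound 2 (2.08 log units; beyond the scatter), concerns the group on the saturated chain carbon and not the amide nitrogen, so it gives no direct guide. Compound 1, which carries a small alkyl on that nitrogen, sits far above compound 3, and compound 4 is expected to land near that level, a step of a 300-fold higher number from compound 3 to compound 4 (2.48 log units; beyond the scatter). The estimate for compound 4 is 120 nM, with a range from 20 nM to 700 nM.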

Compound 4, half-maximal effective concentration: 900 nM
For compound 4 the middle estimate is 7.5-fold (0.88 log units) below the measured one; measured number above the stated range.
By their numbers in this assay, from the lowest: compound 3; then compound 1; then compound 4; then compound 2.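

Putting isobutyl in place of 3-methyl-1H-pyrazol-4-yl on the amide-type nitrogen gives a 2300-fold higher number from compound 3 to compound 4 (3.35 log units; beyond the scatter) in this assay, so the group at this position can move the read-out strongly. The change takes away a ring together with the hydrogen-bond donor and acceptor counted there, and the two compounds cannot separate these features. No measurement shown accounts for the size of this step. Still open, going by these compounds, is whether a plain phenyl ring on that nitrogen would keep the low number, or whether the ring nitrogens are needed.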